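The source may report more compounds than this note shows. Statements on the series, on what has been measured and on what is new or still open speak of the compounds shown alone.

Measured so far in a functional assay on cells (T-cell, Homo sapiens) for inhibition; on this read-out lower numbers stand for stronger inhibition and higher numbers for weaker inhibition:

- compound 1, `COc1ccc(-c2cnc3nc(N)nc(N4CCN(C(=O)NCc5ccc(F)cc5)CC4)c3n2)cc1OC` — 37 nM
- compound 2, `CC(C)Oc1nc(N)nc2ncc(-c3ccc(F)c(F)c3)nc12` — 10000 nM
- compound 3, `COc1ccc(-c2cnc3nc(N)nc(NC(C)C)c3n2)cc1OC` — 600 nM

Compound 1 gives the lowest number of the three in this assay. Compound 3, with the shared core carrying the same dimethoxyphenyl group but a propan-2-ylamino group in place of the piperazine urea, sits clearly higher, beyond the scatter. Compound 2, with a different aryl group and a propan-2-yloxy group on the core, lies furthest away, at a number that reads as essentially inactive on this read-out.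

The next compound, compound 4, `COc1ccc(-c2cnc3nc(N)nc(N4CCN(C(=O)Nc5cccc(C)c5)CC4)c3n2)cc1OC`, keeps everything of compound 1 except the substituent on the urea nitrogen: 3-methylphenyl in place of 4-fluorobenzyl on an amide-type nitrogen. Among the compounds with values here, no measured pair shows this kind of change on the urea, so there is nothing to anchor the size of the step. Both groups are single carbon-only aromatic rings without donors or acceptors, and the replacement is small in count. The expectation is a step of modest size, possibly within the scatter, with a slight lean toward a higher number; the step from compound 1 to compound 4 is estimated at a 1.6-fold higher number from compound 1 to compound 4 (0.21 log units; within the scatter). For compound 4 the estimate in this assay is 60 nM, in a range from 15 nM to 300 nM.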

Compound 4, half-maximal inhibitory concentration: 7 nM
Compound 4: the middle estimate sits 8.6-fold (0.93 log units) above what was measured, outside the stated range (below it).
By their numbers in this assay, from the lowest: compound 4; then compound 1; then compound 3; then compound 2.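

In this assay the substituent on the urea's amide-type nitrogen proves able to move the number: 3-methylphenyl in place of 4-fluorobenzyl gives a 5.3-fold lower number from compound 1 to compound 4 (0.72 log units; beyond the scatter) and leaves compound 4 at 7 nM in this series. The earlier compounds shown here held only one substituent at this place, so they gave no view of how far it could shift the read-out. Both groups hold one six-membered aromatic ring of carbon only with no hydrogen-bond donors or acceptors, so those counts do not separate them, and no measurement at hand bears on the reason for the step.

The change alters the benzyl carbon link and the ring substituent together, and a 3-methylbenzyl or 4-fluorophenyl group on the same nitrogen would separate the two. Still open, on these data alone, is how the read-out responds to a ring carrying an amine or a carboxylic acid here.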